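From compound 3 to compound 4: difluorophenyl for bromophenyl

A few compounds are considered here, and "the series" means these few. Any claim that something is new, unique, unknown or untested is made for them only; others in the source may bear on it.

In a functional assay on A549 cells (Homo sapiens) for inhibition, read by MTT assay, with a stated time of 48 h (a lower number here means a stronger inhibitor, a higher number a weaker inhibitor), compound 1 `Fc1ccc(/C=N/Nc2nc(-c3ccc(C(F)(F)F)cc3)cs2)cc1F` gives 2610 nM. Compound 2 `COc1cc(/C=N/Nc2nc(-c3ccc(F)c(F)c3)cs2)c(Br)c(Br)c1OC`, which carries the 3,4-difluorophenyl on the shared core but a different aldehyde-derived part, gives 8380 nM. For compound 3 `Fc1ccc(/C=N/Nc2nc(-c3ccc(Br)cc3)cs2)cc1F` this assay reports only a limit, > 100000 nM, which places compound 3 at the weak end of the three numbers shown. Among the measured compounds shown here, the one measured step that bears on compound 3 is an at least 38-fold higher number from compound 1 to compound 3 (1.58 log units; beyond the scatter); that step rests on (the limit of > 100000 nM in this assay, at which 1 of the 3 values shown sits), so its true size is not known beyond the bound. Compound 4 `Fc1ccc(/C=N/Nc2nc(-c3ccc(F)c(F)c3)cs2)cc1F` differs from compound 3 in one place: 3,4-difluorophenyl in place of 4-bromophenyl on an aromatic carbon. For the measured compounds named here, no measured pair shows this exact swap, so the comparison is indirect: compound 2 shows that the 3,4-difluorophenyl on the shared core goes with a numerical reading in this assay, while the 4-bromophenyl of compound 3 sits at the limit. The expected step is an at least 8.3-fold lower number from compound 3 to compound 4 (0.92 log units; beyond the scatter), a drop in the number, though its size is uncertain and a second limit cannot be excluded. Compound 4 is estimated at 12000 nM, between 3000 nM and 70000 nM in this assay.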

Compound 4, half-maximal inhibitory concentration: 8490 nM
The estimate for compound 4 lay 1.4-fold (0.15 log units) above the measured number; measured number inside the range.
By their numbers in this assay, from the lowest: compound 1; then compounds 2 and 4 (each within the scatter of the next). At a limit, above all of these: compound 3.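

In this assay, the 3,4-difluorophenyl in place of 4-bromophenyl, on an aromatic carbon of a five-membered aromatic ring with 1 nitrogen and 1 sulfur, gives an at least 11-fold lower number from compound 3 to compound 4 (1.07 log units; beyond the scatter), with the rest of the molecule unchanged. Compound 4 shares its aldehyde-derived part with compounds 1 and 3, so the missing numerical reading of compound 3 goes with the 4-bromophenyl at this position and not with that shared part; among these three compounds, the aryl groups bearing trifluoromethyl and two fluorines both give numerical readings. The size of the step is only a bound, since compound 3 stands at a limit of the assay: the limit of > 100000 nM in this assay, at which 1 of the 4 values shown sits.

Among the compounds shown here, only three aryl groups at this position can be compared on this aldehyde-derived part, so it remains open whether a numerical reading would persist with a 4-aminophenyl, a 4-carboxyphenyl or a 4-methoxyphenyl. Also open, going by these compounds, is whether 4-bromophenyl would go with a limit on a different aldehyde-derived part, such as that of compound 2.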